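A few compounds are considered here, and "the series" means these few. Any claim that something is new, unique, unknown or untested is made for them only; others in the source may bear on it.

Measured so far in an ADME assay on HaCaT cells (Homo sapiens) for cytotoxicity, read by MTT assay, with a stated time of 72 h; a higher number here means a weaker inhibitor, a lower number a stronger inhibitor:
compound 1 `Cc1ccc(CSc2cc(Cl)c(C)cc2S(=O)(=O)/N=C(\N)n2nc(C)cc2-c2ccccc2)cc1` — 30000 nM
compound 2 `Cc1cc(-c2ccccc2)n(/C(N)=N/S(=O)(=O)c2cc(C)c(Cl)cc2SCc2cccc(C(F)(F)F)c2)n1` — 40000 nM
compound 3 `Cc1cc(S(=O)(=O)/N=C(\N)n2nccc2-c2ccccc2)c(SCc2ccccc2C)cc1Cl` — 18000 nM

All three values sit close together. Compound 1 has compound 2 as its nearest neighbour: a 1.3-fold higher number from compound 1 to compound 2 (0.12 log units; within the scatter). Compound 3 is the furthest from compound 1, yet the gap between the value of compound 1 and that of compound 3 is still within the usual scatter, so no order among the three can be read from these numbers.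

Compound 4 `Cc1ccc(CSc2cc(Cl)c(C)cc2S(=O)(=O)/N=C(\N)n2nccc2-c2ccccc2)cc1` differs from compound 1 in one place: hydrogen in place of methyl on an aromatic carbon. Among the compounds with values here, no measured step changes this position; the only measured step, the one already given, concerns the group on the saturated chain carbon bound to a sulfur and lies within the scatter. Compound 3 also carries a hydrogen at this ring carbon, but it differs from compound 1 elsewhere as well, so it gives only loose guidance; its value and that of compound 1 are within the scatter of each other.

The expectation for compound 4 in this assay is therefore a step within the scatter, a 1.2-fold lower number from compound 1 to compound 4 (0.08 log units; within the scatter). The estimated value for compound 4 is 25000 nM, with a range from 10000 nM to 60000 nM.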

Compound 4, half-maximal inhibitory concentration: 20000 nM
The estimate for compound 4 lay 1.3-fold (0.10 log units) above the measured number, and the stated range covers the measured number.
By their numbers in this assay, from the lowest: compounds 3, 4, 1 and 2 (each within the scatter of the next, the first and the last beyond it).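

In this assay, within the data shown here, the only measured step at this carbon of the five-membered aromatic ring, hydrogen in place of methyl, is a 1.5-fold lower number from compound 1 to compound 4 (0.18 log units; within the scatter) and so gives no readable change at this position. Compound 4 also adds a step on the saturated chain carbon bound to a sulfur, where 4-methylphenyl in place of 2-methylphenyl gives a 1.1-fold higher number from compound 3 to compound 4 (0.05 log units; within the scatter) and thus, at this place too, a change that cannot be read. No measurement available here bears on why these values stay so close.

Going by these compounds, whether a larger group at this ring carbon, such as a longer chain, an amine or a carboxylic acid, would move the number beyond the scatter stays open. The same question stands for an amine or a carboxylic acid on the phenyl group on the saturated chain carbon.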